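The source may hold more compounds than are shown below. What is called first, only, known or untested is meant among the compounds shown, and "the series" means these compounds.

Three compounds have so far been measured in an in vivo ADME assay on the whole organism (strain Mongrel) for pharmacokinetics, with Canis familiaris (Canis lupus familiaris) as the target; on this read-out lower numbers stand for slow clearance and higher numbers for fast clearance:

Compound 1, `C[C@@H](NC(=O)C1(NC(=O)c2ccc(Br)nc2)CC1)c1ccc(-n2nc(Cl)c3ccccc32)cc1F`: 2.6 mL/min/kg
Compound 2, `C[C@@H](NC(=O)C1(NC(=O)c2cncc(Cl)c2)CC1)c1ccc(-n2nc(Cl)c3ccccc32)cc1F`: 3.1 mL/min/kg
Compound 3, `COc1cncc(C(=O)NC2(C(=O)N[C@H](C)c3ccc(-n4nc(Cl)c5ccccc54)cc3F)CC2)c1`: 5.5 mL/min/kg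

Compound 1 holds the lowest of the three numbers. The nearest number is reached in a 1.2-fold higher number from compound 1 to compound 2 (0.08 log units; within the scatter), a step within the scatter; the furthest in a 2.1-fold higher number from compound 1 to compound 3 (0.33 log units; beyond the scatter), a modest step that lies beyond it. Between the other two, a 1.8-fold higher number from compound 2 to compound 3 (0.25 log units; within the scatter) stays within the scatter.

Compound 4, `Cc1nnsc1C(=O)NC1(C(=O)N[C@H](C)c2ccc(-n3nc(Cl)c4ccccc43)cc2F)CC1`, has not yet been measured in this assay. It differs from compound 1 in one place: 4-methyl-1,2,3-thiadiazol-5-yl in place of 6-bromopyridin-3-yl on a carbonyl carbon. The two measured steps that bear on this change, a 1.2-fold higher number from compound 1 to compound 2 (0.08 log units; within the scatter) and a 2.1-fold higher number from compound 1 to compound 3 (0.33 log units; beyond the scatter), also exchange the group on the same carbonyl carbon, and both move the number up by little. Going by the values given here, no measured compound carries a five-membered ring with three hetero atoms in this position, so the guidance is indirect. Relative to compound 1, the step to compound 4 is expected to be small, a 1.5-fold higher number from compound 1 to compound 4 (0.19 log units; within the scatter), and not to pass the scatter. The estimate for compound 4 in this assay is 4 mL/min/kg, with a range from 2 mL/min/kg to 8 mL/min/kg.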

Compound 4, clearance: 9.6 mL/min/kg
The estimate for compound 4 lay 2.4-fold (0.38 log units) below the measured number, and the stated range ends below it.
By their numbers in this assay, from the lowest: compounds 1, 2, 3 and 4 (each within the scatter of the next, the first and the last beyond it).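

In this assay the group on this carbonyl carbon proves able to move the number further than the pyridine-bearing compounds alone had shown: 4-methyl-1,2,3-thiadiazol-5-yl gives a 3.7-fold higher number from compound 1 to compound 4 (0.57 log units; beyond the scatter) and a 3.1-fold higher number from compound 2 to compound 4 (0.49 log units; beyond the scatter), each step beyond the scatter. Against 5-methoxypyridin-3-yl the same group gives a 1.7-fold higher number from compound 3 to compound 4 (0.24 log units; within the scatter), which stays within the scatter, so the two cannot be told apart on this read-out. No measurement at hand offers an explanation for the larger steps.

The compounds shown leave open whether the five-membered ring, its hetero atoms or its methyl group accounts for these steps. From the compounds shown here alone, it also remains open how an unsubstituted 1,2,3-thiadiazol-5-yl or a 4-methylthiazol-5-yl would read on the same carbonyl carbon.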